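The source may hold more compounds than are shown below. What is called first, only, known or untested is meant among the compounds shown, and "the series" means these compounds.

In a functional assay on Huh-7 cells (Homo sapiens) for cytotoxicity, read by MTT assay, with a stated time of 48 h (on this read-out lower numbers stand for stronger inhibition and higher numbers for weaker inhibition), compound 1 `O=C1C(Br)=C[C@H]2CO[C@@H]1O2` gives 4680 nM and compound 2 `O=C1C[C@H](Sc2ccccc2)[C@H]2CO[C@@H]1O2` gives 11000 nM. Compound 2 therefore has the higher of the two numbers, meaning weaker inhibition, and the gap lies beyond the scatter. Compound 3 `Cc1ccc(S[C@H]2CC(=O)[C@@H]3OC[C@H]2O3)cc1` differs from it in one place: methyl in place of hydrogen on an aromatic carbon. For the measured compounds named here, no measured pair shows this change, so in this assay only a small move toward a lower number is expected, possibly within the scatter: the estimated 1.2-fold lower number from compound 2 to compound 3 (0.09 log units; within the scatter). Compound 3 is expected at 9000 nM, with an estimated range of 4000 nM to 20000 nM.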

Compound 3, half-maximal inhibitory concentration: 12800 nM
Compound 3: the middle estimate sits 1.4-fold (0.15 log units) below what was measured; low and high end bracket the measured number.
By their numbers in this assay, from the lowest: compound 1; then compounds 2 and 3 (each within the scatter of the next).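

With methyl in place of hydrogen on an aromatic carbon, para to a large group, this assay shows a 1.2-fold higher number from compound 2 to compound 3 (0.07 log units; within the scatter), so the two compounds cannot be told apart. For the compounds shown here, this is the first one-place comparison here, and it shows that this single added carbon at this position does not clearly shift the cell read-out. No measurement here offers an explanation for this result. As far as these compounds go, whether an amine, a carboxylic acid or a longer chain at the same place would give a different number remains open. So does the effect of a methyl on another aromatic carbon.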